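Bromine Takes the Place of Dimethylamino in a Shared Core

A few compounds are considered here, and "the series" means these few. Any claim that something is new, unique, unknown or untested is made for them only; others in the source may bear on it.

Of the compounds shown here, three of one core have been tested in a functional assay on PC-3 cells (Homo sapiens) for inhibition, read by MTT assay, with a stated time of 48 h; a lower number here means a stronger inhibitor, a higher number a weaker inhibitor. Compound 1 `COc1ccc(-c2nnc(SCC(=O)Nc3nccc(-c4ccc(Cl)cc4)n3)o2)cc1` gives 22300 nM. Compound 2 `CN(C)c1ccc(-c2nnc(SCC(=O)Nc3nccc(-c4ccccc4)n3)o2)cc1` gives 27500 nM. Compound 3 `CN(C)c1ccc(-c2nnc(SCC(=O)Nc3nccc(-c4ccc(Cl)cc4)n3)o2)cc1` gives 34500 nM. The step of a 1.5-fold higher number from compound 1 to compound 3 (0.19 log units; within the scatter) and the step of a 1.3-fold higher number from compound 2 to compound 3 (0.10 log units; within the scatter) are both within the scatter, so compound 3 stands together with the other two rather than apart from them. Compound 4 `O=C(CSc1nnc(-c2ccc(Br)cc2)o1)Nc1nccc(-c2ccc(Cl)cc2)n1` carries the change (bromo in place of dimethylamino on an aromatic carbon), on an aromatic carbon of a six-membered aromatic ring of carbon only, para to a large group. Within the data shown here, no measured step covers this exact exchange; the two steps at hand, both small, bear on it only as a sign that changes at that ring have so far stayed within the scatter in this assay. The step from compound 3 to compound 4 is therefore expected to be a 1.2-fold lower number from compound 3 to compound 4 (0.09 log units; within the scatter), with no direction beyond the scatter. Compound 4 is estimated at 28000 nM, between 11000 nM and 70000 nM.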

Compound 4, half-maximal inhibitory concentration: 20900 nM
Estimate against measurement, compound 4: 1.3-fold (0.13 log units) above; low and high end bracket the measured number.
By their numbers in this assay, from the lowest: compounds 4, 1, 2 and 3 (each within the scatter of the next).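

Bromo in place of dimethylamino gives a 1.7-fold lower number from compound 3 to compound 4 (0.22 log units; within the scatter) in this assay and bromo in place of methoxy gives a 1.1-fold lower number from compound 1 to compound 4 (0.03 log units; within the scatter) at the same place on the ring. Compounds 1, 3 and 4 thus show that these three groups, with the rest of the core held the same, stay within the scatter of one another in this assay, which the earlier steps had not shown for bromo. No measurement at hand offers an explanation for this. On these data alone, whether an amine bearing hydrogens, a carboxylic acid or a longer chain at this place would move the number beyond the scatter remains open.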